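Compound 4: cyclopropyl on the amine nitrogen

A few compounds are considered here, and "the series" means these few. Any claim that something is new, unique, unknown or untested is made for them only; others in the source may bear on it.

Measured so far in a physicochemical assay for solubility, read by HPLC; on this read-out higher numbers stand for higher solubility and lower numbers for lower solubility:
- compound 1 `CC(=O)NC[C@H]1CN(c2ccc(OC[C@H](O)CNc3ccc(C#N)cc3)c(F)c2)C(=O)O1`: 69000 nM
- compound 2 `CC(=O)NC[C@H]1CN(c2ccc(OC[C@H](O)CNc3cccnc3)c(F)c2)C(=O)O1`: 10100000 nM
- compound 3 `CC(=O)NC[C@H]1CN(c2ccc(OC[C@H](O)CNc3ccncc3)c(F)c2)C(=O)O1`: 24600000 nM

Among these three, compound 3 has the highest number, at 24600000 nM. The next compound, compound 4 `CC(=O)NC[C@H]1CN(c2ccc(OC[C@H](O)CNC3CC3)c(F)c2)C(=O)O1`, has cyclopropyl in place of pyridin-4-yl on an amine nitrogen.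

Among the compounds with values here, three measured steps bear on this change, all at the same place. Leaving 4-cyanophenyl gave two large steps: a 150-fold higher number from compound 1 to compound 2 (2.17 log units; beyond the scatter) and a 360-fold higher number from compound 1 to compound 3 (2.55 log units; beyond the scatter). Exchanging pyridin-3-yl for pyridin-4-yl gave a modest one: a 2.4-fold higher number from compound 2 to compound 3 (0.39 log units; beyond the scatter). Within the data shown here, none of them puts a non-aromatic ring on this nitrogen, so the data hold no direct precedent, and the large steps show that this place can move the number far in this assay.

Compound 1 stands alone at 69000 nM, and compound 4 is expected to stay nearer the top of the series than that. The expected change is a modest fall, stated as a 2.5-fold lower number from compound 3 to compound 4 (0.39 log units; beyond the scatter). For compound 4 the estimate is 10000000 nM, with an expected range from 2000000 nM to 30000000 nM.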

Compound 4, solubility: 2200000 nM
Compound 4: middle estimate off by 4.5-fold (0.66 log units), on the high side; the measured number falls inside the stated range.
By their numbers in this assay, from the lowest: compound 1; then compound 4; then compound 2; then compound 3.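

In this assay, within the data shown here, the amine nitrogen now carries a non-aromatic ring for the first time, and the result sits inside the spread of the aromatic groups rather than outside it: an 11-fold lower number from compound 3 to compound 4 (1.05 log units; beyond the scatter) and a 4.6-fold lower number from compound 2 to compound 4 (0.66 log units; beyond the scatter) place cyclopropyl below both pyridines, while a 32-fold higher number from compound 1 to compound 4 (1.50 log units; beyond the scatter) places it above 4-cyanophenyl. Aromatic character alone therefore does not order the series, with compound 1 going against any rule that aromatic groups give the higher numbers and compound 4 going against any rule that non-aromatic groups do, and the smaller group leaving pyridin-4-yl did not bring a higher number. Nothing available on these compounds accounts for this order.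

The change from pyridin-4-yl to cyclopropyl alters ring size, aromatic character and the ring nitrogen all at once, so the step from compound 3 does not say which of these carries the fall. Unsubstituted phenyl would separate the ring nitrogen from the nitrile among the aromatic groups, and piperidin-4-yl, a saturated six-membered ring holding a nitrogen, would test whether that ring nitrogen keeps the number high without aromatic character.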